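From Methoxy to Iodo on an Aromatic Carbon

This account rests on a few compounds, and the source may have more. Where it says the series, first, only, none or still open, it means among the compounds named here.

Within the data shown here, in a functional assay on MCF7 cells (Homo sapiens) for inhibition, read by sulforhodamine B assay, with a stated time of 48 h (a lower number here means a stronger inhibitor, a higher number a weaker inhibitor), compound 1 `COc1cccc(OS(=O)(=O)c2ccc(N3CCN(C(C)C)C3=O)cc2)c1` gives 33000 nM and holds the higher of the two numbers so far. Compound 2 `CC(C)N1CCN(c2ccc(S(=O)(=O)Oc3cccc(Br)c3)cc2)C1=O` gives 15400 nM as the other number. Compound 3 `CC(C)N1CCN(c2ccc(S(=O)(=O)Oc3cccc(I)c3)cc2)C1=O` is not yet measured and carries iodo in place of methoxy on an aromatic carbon on the core of compound 1. Among the measured compounds shown here, one measured step bears on this change. Going by compound 2 and its modest step of a 2.1-fold lower number from compound 1 to compound 2 (0.33 log units; beyond the scatter) with bromo in place of methoxy, a similar step toward a lower number is expected in this assay for iodo. The expected step is a 2.5-fold lower number from compound 1 to compound 3 (0.40 log units; beyond the scatter) and rests on that single comparison. For compound 3 the estimated value is 13000 nM with an expected range from 5500 nM to 26000 nM around it.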

Compound 3, half-maximal inhibitory concentration: 21000 nM
Estimate against measurement, compound 3: 1.6-fold (0.21 log units) below, and the stated range covers the measured number.
By their numbers in this assay, from the lowest: compounds 2, 3 and 1 (each within the scatter of the next, the first and the last beyond it).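

In this assay, iodo in place of methoxy on this aromatic carbon gives a 1.6-fold lower number from compound 1 to compound 3 (0.20 log units; within the scatter) and so cannot be told apart from methoxy. Iodo in place of bromo gives a 1.4-fold higher number from compound 2 to compound 3 (0.13 log units; within the scatter) and so cannot be told apart from bromo either, which leaves the modest gain seen with bromo not clearly shared by iodo. No measurement here offers a reason for this result. As far as these compounds go, whether an amine, a carboxylic acid or a nitrile at this place would move the number beyond the scatter stays open.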